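Anilino Out, Furan-2-yl In on the Shared Core

The source may hold more compounds than are shown below. What is called first, only, known or untested is meant among the compounds shown, and "the series" means these compounds.

Compound 1, `O=C(/N=C1\NC2(CCCCO2)CCS1)Nc1ccccc1`: in a functional assay on the whole organism (strain CF-1) with Mus musculus as the target, in the writhing test, with a stated time of 15 min (on this read-out higher numbers stand for an effect only at larger amounts of compound and lower numbers for an effect already at smaller amounts), compound 1 gives > 200 mg/kg, which is a limit of the assay and not a number.
Compound 2, `O=C1c2ccccc2C(=O)N1C1=NC2(CCCCO2)CCS1`: in this assay compound 2 gives 14.8 mg/kg.

Compound 1 therefore stands only at the limit of > 200 mg/kg in this assay, at which 1 of the 2 values shown sits, so its place among the numbers is known merely as a boundary, not as a value. Compound 3, `O=C(/N=C1\NC2(CCCCO2)CCS1)c1ccco1`, arises from compound 1 through (furan-2-yl in place of anilino on a carbonyl carbon). Going by the values given here, no measured pair shows this kind of change, so the size of the step cannot be taken from the data. Compound 2 shows that the shared core can carry an effect within the measured range once the group on the exocyclic nitrogen is altered, but that change is a different one. The step is expected to be a move towards smaller amounts, an at least 2.2-fold lower number from compound 1 to compound 3 (0.34 log units; beyond the scatter), though with wide uncertainty. Compound 3 is expected to give 90 mg/kg, with a range from 20 mg/kg to 200 mg/kg.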

Compound 3, dose for half-maximal effect: 42 mg/kg
The estimate for compound 3 lay 2.1-fold (0.33 log units) above the measured number, and the stated range covers the measured number.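

Keeping the carbonyl and replacing anilino with furan-2-yl is enough to bring the compound within the measured range: in this assay the change gives an at least 4.7-fold lower number from compound 1 to compound 3 (0.67 log units; beyond the scatter). Going by these compounds alone, compound 2 had already reached that range, but through a different change, so only this step speaks to the group on the carbonyl carbon. Its size is a lower bound only, because compound 1 stands at a limit of the assay and not at a number: the limit of > 200 mg/kg in this assay, at which 1 of the 3 values shown sits.

The compounds shown leave open whether the gain depends on furan-2-yl itself or follows from the loss of anilino, a question that phenyl, thiophen-2-yl or methyl on the same carbonyl carbon would address. Going by these compounds, the true size of the step also remains unknown.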